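A Pyridine for a Cyclohexene: Cytotoxicity Expected Unchanged

A few compounds are considered here, and "the series" means these few. Any claim that something is new, unique, unknown or untested is made for them only; others in the source may bear on it.

Compound 1, `O=C1O/C(=C\Cn2cc(C3=CCCCC3)nn2)C(OCc2ccccc2)=C1OCc1ccccc1`: > 100000 nM
Compound 2, `CCCc1cn(CCC2(O)C(OCc3ccccc3)=C(OCc3ccccc3)C(=O)N2CCC)nn1`: 90000 nM
Compound 3, `O=C1NC(O)(CCn2cc(-c3ccccc3)nn2)C(OCc2ccccc2)=C1OCc1ccccc1`: > 100000 nM

These three compounds were tested in an ADME assay on HEK293 cells (Homo sapiens) for cytotoxicity, read by MTT assay, with a stated time of 24 h; a lower number here means a stronger inhibitor, a higher number a weaker inhibitor. Compound 1 gives only > 100000 nM there, which is a limit of this assay rather than a number. Compound 3 likewise reaches only a limit, > 100000 nM. Compound 2 gives a number, 90000 nM. Compound 1 thus stands where most of the set sits, at the limit of > 100000 nM in this assay, at which 2 of the 3 values shown sit. Compound 4, `O=C1O/C(=C\Cn2cc(-c3ccccn3)nn2)C(OCc2ccccc2)=C1OCc1ccccc1`, is not yet measured. It differs from compound 1 in one place: pyridin-2-yl in place of cyclohex-1-en-1-yl on an aromatic carbon. Going by the values given here, no measured step of this kind exists here, so the change is expected to move the read-out by no more than the scatter in either direction. The step of a number no higher from compound 1 to compound 4 (the limit leaves the size open) is expected to be small. Compound 4 is therefore expected at 100000 nM, between 50000 nM and 300000 nM, most likely reported again as a limit.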

Compound 4, half-maximal inhibitory concentration: > 100000 nM
Compound 4: no number, only a limit; the forecaster's own chance of this, stated with the estimate: 70%; the middle value lies on the limit itself.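

Going by these compounds alone, compound 1 and compound 4 each give only a limit, not a number, so no step between them can be read. Both sit with most of the set: the limit of > 100000 nM in this assay, at which 3 of the 4 values shown sit. The compounds shown leave open whether pyridin-2-yl in place of cyclohex-1-en-1-yl changes the read-out at all.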